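The source may hold more compounds than are shown below. What is called first, only, known or untested is meant among the compounds shown, and "the series" means these compounds.

Compound 1 `CC(C)CCn1cnc2c(Nc3cccc(Cl)c3)nc(N[C@H]3CC[C@H](N)CC3)nc21` gives 2100 nM
Compound 2 `CCCCn1cnc2c(Nc3cccc(Cl)c3)nc(N[C@H]3CC[C@H](N)CC3)nc21` gives 2000 nM

Among the measured compounds shown here, both values come from a functional assay on MCF7 cells (Homo sapiens) for inhibition, read by fluorescence, with a stated time of 72 h (a lower number here means a stronger inhibitor of growth, a higher number a weaker inhibitor of growth), where compound 2 stands within the scatter of compound 1, the only other measured compound. Compound 3 `N[C@H]1CC[C@H](Nc2nc(Nc3cccc(Cl)c3)c3ncn(Cc4ccccc4)c3n2)CC1` follows from compound 2 through phenyl in place of propyl on a saturated chain carbon bound to an aromatic nitrogen and thus has phenyl in place of propyl on a saturated chain carbon bound to an aromatic nitrogen. The same difference reads butyl to benzyl. For the measured compounds named here, one measured step bears on this chain: a 1.1-fold lower number from compound 1 to compound 2 (0.02 log units; within the scatter) with hydrogen in place of methyl on a saturated chain carbon bound to two saturated chain carbons. Going by the values given here, that step brought in no ring, and no measured compound carries one on this chain, which leaves the expectation uncertain. No change beyond the scatter is expected, and the estimated 1.1-fold lower number from compound 2 to compound 3 (0.05 log units; within the scatter) reflects that. Compound 3 is estimated at 1800 nM with a range from 500 nM to 6000 nM as the expected span.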

Compound 3, concentration for 50% growth inhibition: 3600 nM
Beside the measured number, compound 3's estimate is 2.0-fold (0.30 log units) below it, within the range that was stated.
By their numbers in this assay, from the lowest: compounds 2, 1 and 3 (each within the scatter of the next).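

In this assay, the saturated chain carbon bound to an aromatic nitrogen now carries a phenyl ring, which compounds 1 and 2 lack, and the change from butyl to benzyl gives a 1.8-fold higher number from compound 2 to compound 3 (0.26 log units; within the scatter). Measured against the branched chain, the ring gives a 1.7-fold higher number from compound 1 to compound 3 (0.23 log units; within the scatter), so among these three compounds neither open chain differs from benzyl beyond the scatter, and a ring is tolerated here without a measurable loss of growth inhibition. No measurement is at hand that would explain these numbers.

Going by these compounds, whether an amine or a carboxylic acid on this chain would shift the number beyond the scatter remains open. The same holds for a longer chain between the aromatic nitrogen and the phenyl ring, and for a pyridine ring in place of phenyl.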